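Swapping the ring at the chain carbon of an EP3 antagonist

The source may report more compounds than this note shows. Statements on the series, on what has been measured and on what is new or still open speak of the compounds shown alone.

Three compounds sharing one core were tested in a functional assay on CHO cells for antagonist activity at prostaglandin E2 receptor EP3 subtype (Homo sapiens), read by cAMP accumulation; on this read-out lower numbers stand for stronger inhibition and higher numbers for weaker inhibition. Compound 1 `CC(C)C(c1ccc(-c2ccc3cccc(F)c3c2)[nH]c1=O)N1CCCCS1(=O)=O` gives 122 nM, compound 2 `CC(C)C(c1ccc(-c2ccc3cccc(F)c3c2)[nH]c1=O)N1CCCCC1=O` gives 40 nM, and compound 3 `CC(C)C(c1ccc(-c2ccc3cccc(F)c3c2)[nH]c1=O)N1CCN/C1=N\C#N` gives 38 nM, the lowest of the three numbers, though its gap to compound 2 lies within the scatter. Compound 4 `Cc1nc(C(c2ccc(-c3ccc4cccc(F)c4c3)[nH]c2=O)C(C)C)[nH]c1C` carries a change at the same place: a group of 7 heavy atoms (5 carbon, 2 nitrogen; one five-membered aromatic ring with 2 hetero atoms) in place of a group of 8 heavy atoms (4 carbon, 4 nitrogen; one five-membered non-aromatic ring with 2 hetero atoms), on a saturated chain carbon bound to an aromatic carbon and a saturated chain carbon. Earlier swaps at that position moved the number by a 3.1-fold lower number from compound 1 to compound 2 (0.48 log units; beyond the scatter) and a 3.2-fold lower number from compound 1 to compound 3 (0.51 log units; beyond the scatter), while a 1.1-fold lower number from compound 2 to compound 3 (0.02 log units; within the scatter). Another swap of this kind is therefore expected to shift this assay by little, if at all, beyond the scatter. Compound 4 is estimated at 50 nM, within 15 nM to 170 nM, which means an expected step of a 1.3-fold higher number from compound 3 to compound 4 (0.12 log units; within the scatter).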

Compound 4, half-maximal inhibitory concentration: 50 nM
Estimate against measurement, compound 4: no gap at the digits printed; the measured number falls inside the stated range.
By their numbers in this assay, from the lowest: compounds 3, 2 and 4 (each within the scatter of the next); then compound 1.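

With 4,5-dimethyl-1H-imidazol-2-yl, an aromatic ring now sits on this saturated chain carbon, and the read-out stays level with the two best non-aromatic rings (a 1.3-fold higher number from compound 3 to compound 4 (0.12 log units; within the scatter); a 1.3-fold higher number from compound 2 to compound 4 (0.10 log units; within the scatter)). Compound 1, with its sulfur-containing ring, remains the only one set apart (a 2.4-fold lower number from compound 1 to compound 4 (0.39 log units; beyond the scatter)). No measurement here bears on what lies behind this pattern. Open is whether the two methyl groups of the new ring matter, as no unmethylated imidazole appears among these compounds. A carboxylic acid or an open-chain amine on this carbon also remains untested in what is shown.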